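This account rests on a few compounds, and the source may have more. Where it says the series, first, only, none or still open, it means among the compounds named here.

Measured so far in a functional assay on MDA-MB-231 cells (Homo sapiens) for inhibition, with a stated time of 72 h; a higher number here means a weaker inhibitor, a lower number a stronger inhibitor:
compound 1, `COc1ccc(NC(=O)Nc2nc(Sc3c[nH]c4ccccc34)cc(N3CCN(c4ccccn4)CC3)n2)cc1`, gives 28400 nM
compound 2, `O=C(Nc1ccccc1)Nc1nc(Sc2c[nH]c3ccccc23)cc(N2CCN(Cc3ccccc3)CC2)n1`, gives 10200 nM
compound 3, `Cc1ccc(C)c(NC(=O)Nc2nc(Sc3c[nH]c4ccccc34)cc(N3CCN(Cc4ccccc4)CC3)n2)c1`, gives 19000 nM

Compound 3 stands at the second highest of the three numbers. Its nearest neighbour is compound 1 and its furthest is compound 2, and both gaps lie within the scatter, so the three measured compounds cannot be ranked against one another on these numbers.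

The next compound, compound 4, `COc1ccc(NC(=O)Nc2nc(Sc3c[nH]c4ccccc34)cc(N3CCN(Cc4ccccc4)CC3)n2)cc1`, differs from compound 3 by 4-methoxyphenyl in place of 2,5-dimethylphenyl on an amide-type nitrogen. Among the compounds with values here, only one measured step touches the same position: a 1.9-fold higher number from compound 2 to compound 3 (0.27 log units; within the scatter), which exchanges the group on the amide-type nitrogen and stays within the scatter. Compound 1 carries the same 4-methoxyphenyl group that enters in compound 4, but it differs from compound 4 elsewhere in the shared core, so it bears on the step only indirectly; its number and that of compound 3 sit within the scatter of each other as well. Within the data shown here, nothing among the measured steps points to a change beyond the scatter in this assay for this exchange.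

The step from compound 3 is expected to be a 1.1-fold lower number from compound 3 to compound 4 (0.02 log units; within the scatter). For compound 4 the estimated value is 18000 nM, with a range from 8000 nM to 40000 nM.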

Compound 4, half-maximal inhibitory concentration: 8920 nM
For compound 4 the middle estimate is 2.0-fold (0.30 log units) above the measured one, and the stated range covers the measured number.
By their numbers in this assay, from the lowest: compounds 4, 2, 3 and 1 (each within the scatter of the next, the first and the last beyond it).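

In this assay the group on the amide-type nitrogen now gives a step beyond the scatter, though only a modest one: a 2.1-fold lower number from compound 3 to compound 4 (0.33 log units; beyond the scatter), with 4-methoxyphenyl entering for 2,5-dimethylphenyl. Plain phenyl and 4-methoxyphenyl, however, stay within the scatter of each other, a 1.1-fold lower number from compound 2 to compound 4 (0.06 log units; within the scatter), so methoxy in place of hydrogen on an aromatic carbon shows no readable change, and compound 3 separates from compound 4 but not from compound 2. The amine nitrogen in a ring gets its first reading in this series, also modest, with benzyl in place of pyridin-2-yl: a 3.2-fold lower number from compound 1 to compound 4 (0.50 log units; beyond the scatter); no measurement shown gives a reason for either step beyond the scatter.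

The compounds shown leave open whether a hydroxyl, a chlorine or an amine on the phenyl would move the number further than methoxy does, and whether the gap between 4-methoxyphenyl and 2,5-dimethylphenyl holds with pyridin-2-yl on the ring nitrogen. They also leave open how a longer chain in place of benzyl, or a carboxylic acid on that group, would read in this assay.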